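Adding a bromo group to compound 1

The source may hold more compounds than are shown below. What is called first, only, known or untested is meant among the compounds shown, and "the series" means these compounds.

In a functional assay on SK-N-SH cells (Homo sapiens) for cytotoxicity, read by MTT assay, with a stated time of 24 h (a higher number here means a weaker inhibitor, a lower number a stronger inhibitor), compound 1 `Nc1cccn2cc(Cc3ccccc3)c(=O)nc12` gives 116000 nM. Two close relatives have also been measured. Compound 2 `Nc1cccn2cc(Cc3ccc(F)cc3)c(=O)nc12` gives 126000 nM, and compound 3 `O=c1nc2ccccn2cc1Cc1ccccc1` gives 95400 nM. Compound 1 therefore has no clear rank among these numbers, since its value lies within the scatter of both the others.

Compound 4 `Nc1cc(Br)cn2cc(Cc3ccccc3)c(=O)nc12` keeps the core of compound 1 and makes one change: bromo in place of hydrogen on an aromatic carbon. It has bromo in place of hydrogen on an aromatic carbon, on the six-membered aromatic ring with 1 nitrogen, two atoms from the ring nitrogen and meta to an amino group.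

Among the compounds with values here, no measured compound carries a bromo group, so the data offer no direct precedent. Within the data shown here, two measured steps bear on the change. Fluoro in place of hydrogen on an aromatic carbon gave a 1.1-fold higher number from compound 1 to compound 2 (0.04 log units; within the scatter). Hydrogen in place of amino on an aromatic carbon gave a 1.2-fold lower number from compound 1 to compound 3 (0.08 log units; within the scatter). Both steps are small, so no step beyond the scatter is expected in this assay, and no direction is favoured with any confidence. The estimated step is a 1.2-fold lower number from compound 1 to compound 4 (0.06 log units; within the scatter). Compound 4 is expected at about 100000 nM, with an estimated range from 50000 nM to 170000 nM.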

Compound 4, half-maximal inhibitory concentration: 149000 nM
Estimate against measurement, compound 4: 1.5-fold (0.17 log units) below; the measured number falls inside the stated range.
By their numbers in this assay, from the lowest: compounds 3, 1, 2 and 4 (each within the scatter of the next).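

In this assay the change is bromo in place of hydrogen on an aromatic carbon, two atoms from the ring nitrogen and meta to an amino group, and it gives a 1.3-fold higher number from compound 1 to compound 4 (0.11 log units; within the scatter). Within the data shown here, the earlier steps removed the amino group or added a fluoro group elsewhere in the molecule, so this is the first look at this carbon and at a bromo group, and it shows that the core of compound 1 can carry a bromine atom here without a step beyond the scatter. Nothing in the data speaks to why the number stays within the scatter.

Going by these compounds, it remains open whether a different group at this carbon, such as a carboxylic acid, a primary amine, a methoxy group or a longer alkyl chain, would produce a step beyond the scatter. On these data alone, it also remains open whether a bromo group on another carbon of the same ring, or one on the benzyl ring of compound 1, would leave the number just as close to that of compound 1.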